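This account rests on a few compounds, and the source may have more. Where it says the series, first, only, none or still open, it means among the compounds named here.

Working notes on the series. Compound 2 `COc1cc(Cn2cc(CNC(=O)c3cn(-c4ccccc4)nc3-c3ccccc3)nn2)cc(OC)c1` and compound 1 `COc1ccc(Cn2cc(CNC(=O)c3cn(-c4ccccc4)nc3-c3ccccc3)nn2)cc1` share one core and differ only at the methoxyphenyl. In a functional assay on HeLa cells (Homo sapiens) for antiproliferative activity, read by sulforhodamine B assay, with a stated time of 48 h (a higher number here means a weaker inhibitor of growth, a lower number a stronger inhibitor of growth), compound 1 gives 6900 nM; compound 2 gives 12200 nM. The step of a 1.8-fold higher number from compound 1 to compound 2 (0.25 log units; within the scatter) is within the scatter, so the two values are not separated. Compound 3 `COc1cc(Cn2cc(CNC(=O)c3cn(-c4ccccc4)nc3-c3ccccc3)nn2)cc(OC)c1OC` follows from compound 2 by methoxy in place of hydrogen on an aromatic carbon. Among the compounds with values here, the only step that bears on this is that one, adding a methoxy to the same ring, and it was within the scatter. For compound 3 no shift beyond the scatter in this assay is expected, a 1.1-fold higher number from compound 2 to compound 3 (0.03 log units; within the scatter). Compound 3 is therefore estimated at 13000 nM, between 4500 nM and 38000 nM.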

Compound 3, concentration for 50% growth inhibition: > 100000 nM
Compound 3 gave a limit, no number; the forecaster's own chance of this, stated with the estimate: 5%; at least 7.6-fold (0.88 log units) between middle value and limit.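

Compound 3 gives a limit of the assay, not a number: the limit of > 100000 nM in this assay, at which 1 of the 3 values shown sits. Methoxy in place of hydrogen on this aromatic carbon, ortho to two methoxy groups and para to a large group, gives an at least 8.1-fold higher number from compound 2 to compound 3 (0.91 log units; beyond the scatter), the first step in the series to pass the scatter. The 3,4,5-trimethoxyphenyl group in place of 4-methoxyphenyl gives an at least 14-fold higher number from compound 1 to compound 3 (1.16 log units; beyond the scatter), so this position separates values where the earlier ring change did not.

From the compounds shown here alone, the full size of the loss in this assay stays open. Also open, going by these compounds, is whether a hydroxyl or an amine on that same carbon would read like methoxy or like hydrogen.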